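A few compounds are considered here, and "the series" means these few. Any claim that something is new, unique, unknown or untested is made for them only; others in the source may bear on it.

Measured compounds:
Compound 1, `CCN(CC)c1ccc2cc(C(=O)c3ccc(N4CCN(C(=O)CN5CCN(S(=O)(=O)C6CC6)CC5)CC4)cc3)oc2c1`; in an ADME assay on L02 cells (Homo sapiens) for cytotoxicity, read by MTT assay, with a stated time of 48 h (a lower number here means a stronger inhibitor, a higher number a weaker inhibitor), compound 1 reads > 100000 nM, which is a limit of the assay and not a number.
Compound 2, `CCN(CC)c1ccc2cc(C(=O)c3ccc(N4CCN(C(=O)CN5CCN(S(=O)(=O)c6ccc(C(F)(F)F)cc6)CC5)CC4)cc3)oc2c1`; in this assay compound 2 gives 17000 nM.

Compound 1 thus stands at the edge of what the assay reports; (the limit of > 100000 nM in this assay, at which 1 of the 2 values shown sits). Within the data shown here, the one measured step, an at least 5.8-fold lower number from compound 1 to compound 2 (0.76 log units; beyond the scatter), exchanges only the group on the sulfonyl sulfur. Compound 3, `CCN(CC)c1ccc2cc(C(=O)c3ccc(N4CCN(C(=O)CN5CCN(Cc6ccc(C(F)(F)F)cc6)CC5)CC4)cc3)oc2c1`, differs from compound 1 by 4-(trifluoromethyl)benzyl in place of cyclopropylsulfonyl on an amine nitrogen in a ring. Among the measured compounds shown here, that change removes the sulfonyl group altogether while bringing in a trifluoromethyl-bearing six-membered aromatic ring of the kind present in compound 2, so the step from compound 1 to compound 2 is the only guide, and it points to a lower number. The expected step is an at least 6.6-fold lower number from compound 1 to compound 3 (0.82 log units; beyond the scatter), downward and beyond the scatter, with wide uncertainty since compound 1 is known only as a limit. Compound 3 is estimated at 15000 nM in this assay, within 4000 nM to 70000 nM.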

Compound 3, half-maximal inhibitory concentration: 6540 nM
Beside the measured number, compound 3's estimate is 2.3-fold (0.36 log units) above it; the range from low to high includes it.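

Putting 4-(trifluoromethyl)benzyl in place of cyclopropylsulfonyl on an amine nitrogen in a ring gives an at least 15-fold lower number from compound 1 to compound 3 (1.18 log units; beyond the scatter) in this assay, so a lower number at this position does not require a sulfonyl group. Compound 2 keeps the sulfonyl group and reads 17000 nM, while compound 3 lacks it and reads 6540 nM, so a number rather than a limit is obtained with either attachment of the trifluoromethyl-bearing aromatic ring. The true size of the step stays unknown because compound 1 is known only as a limit: the limit of > 100000 nM in this assay, at which 1 of the 3 values shown sits.

On these data alone, whether the trifluoromethyl group or the aromatic ring carries the change stays open, with both present in every compound that gives a number. As far as these compounds go, an unsubstituted benzyl would separate the two, and how a carboxylic acid or a longer alkyl chain on this nitrogen would read also remains open.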